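The compounds below may be only part of what the source reports. "The series", "measured", "known", "first", "only" and "open" are said of these compounds alone.

Measured in an in vitro ADME assay on microsomes from liver (Simiiformes) (on this read-out higher numbers stand for a longer-lived compound and lower numbers for a shorter-lived compound), as follows
- Compound 1 `CCc1cc(CCCOc2c(C)cc(-c3noc(C)n3)cc2C)on1` gives 0.183 h
- Compound 2 `Cc1cc(-c2noc(C(F)(F)F)n2)cc(C)c1OCCCc1cc(C[S+](C)[O-])no1` gives > 2.5 h as a limit of the assay and not a number
- Compound 3 `CC(=O)c1ccc(CCCOc2c(C)cc(-c3noc(C(F)(F)F)n3)cc2C)o1` gives 1.05 h

Compound 3 (1.05 h) holds the higher of the two exact numbers, and compound 1 (0.183 h) lies clearly lower. Compound 4 `CC(=O)c1ccc(CCCOc2c(C)cc(-c3noc(C)n3)cc2C)o1` differs from compound 3 in one place (methyl in place of trifluoromethyl on an aromatic carbon), with methyl in place of trifluoromethyl on an aromatic carbon. Among the measured compounds shown here, the only measured step (an at least 2.3-fold lower number from compound 2 to compound 3 (0.37 log units; beyond the scatter)) changes another part of the molecule, so it does not bear directly on this swap. Like compound 4, compound 1 carries 5-methyl-1,2,4-oxadiazol-3-yl and gives 0.183 h while differing elsewhere, so a shorter half-life is expected. The expected size of the change is a 2.3-fold lower number from compound 3 to compound 4 (0.37 log units; beyond the scatter) in this assay, a modest fall. Compound 4 is expected at 0.45 h (estimated range 0.18 h to 1.1 h).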

Compound 4, half-life: 0.617 h
Beside the measured number, compound 4's estimate is 1.4-fold (0.14 log units) below it; the measured number falls inside the stated range.
By their numbers in this assay, from the lowest: compound 1; then compounds 4 and 3 (each within the scatter of the next). At a limit, above all of these: compound 2.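

In this assay the step of a 1.7-fold lower number from compound 3 to compound 4 (0.23 log units; within the scatter) puts methyl in place of trifluoromethyl on the oxadiazole carbon, so this swap alone does not separate the two compounds. The step of a 3.4-fold higher number from compound 1 to compound 4 (0.53 log units; beyond the scatter) puts 5-acetylfuran-2-yl in place of 3-ethyl-1,2-oxazol-5-yl, and that change stands clear of the scatter. Nothing measured here explains either step. On these data alone, whether the methyl swap reads the same with other groups at the chain end stays open. So does what an ethyl or a primary amide would give at this ring carbon.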